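Ester to Pyridine Acid on a Shared Core

The source may hold more compounds than are shown below. What is called first, only, known or untested is meant among the compounds shown, and "the series" means these compounds.

This account follows two compounds that share one core and differ in the group on a saturated chain carbon bound to an amine nitrogen in a ring. Compound 1 `COC(=O)c1ccc(CN2CCC[C@H](O[C@H](CO)c3cc(Cl)cc(Cl)c3)[C@@H]2c2ccccc2)c(C)c1` was tested in an assay on isolated protein for activation of cGMP-dependent protein kinase 1 (Homo sapiens), read by ADP-Glo, with stated times of 30 min and 2 h; a higher number here means that more compound is needed for the effect, a lower number that less compound is needed. In this assay compound 1 reaches only the limit of the assay, > 200000 nM, so no single number is known for it. Compound 2 `Cc1cc(C(=O)O)ccc1CN1CCC[C@H](O[C@H](CO)c2cc(Cl)cc(Cl)c2)[C@@H]1c1cccnc1` is the other entry; for compound 2 this assay gives "nd" (no result reported). For the measured compounds named here, compound 1 therefore stands at the limit of > 200000 nM in this assay, at which 1 of the 2 values shown sits, and no measured step between compounds is at hand. Compound 3 `Cc1nc(C(=O)O)ccc1CN1CCC[C@H](O[C@H](CO)c2cc(Cl)cc(Cl)c2)[C@@H]1c1ccccc1` carries the change (a group of 10 heavy atoms (7 carbon, 1 nitrogen, 2 oxygen; one six-membered aromatic ring with 1 hetero atom) in place of a group of 11 heavy atoms (9 carbon, 2 oxygen; one six-membered aromatic ring of carbon only), on a saturated chain carbon bound to an amine nitrogen in a ring). Going by the values given here, no measured pair shows what this change does, so the direction of the step is open, and an estimate can rest only on the fact that compound 1 sits at the limit. The step from compound 1 to compound 3 is expected to be an at least 6.6-fold lower number from compound 1 to compound 3 (0.82 log units; beyond the scatter). The estimate for compound 3 is 30000 nM, with a range from 3000 nM to 200000 nM, and a real chance that this assay again reports only a limit.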

Compound 3, half-maximal effective concentration: 144000 nM
Beside the measured number, compound 3's estimate is 4.8-fold (0.68 log units) below it; low and high end bracket the measured number.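

Of the compounds shown, compound 3 alone gives a single number in this assay, 144000 nM, so the change on a saturated chain carbon bound to an amine nitrogen in a ring can now be read as a step. That step is an at least 1.3-fold lower number from compound 1 to compound 3 (0.14 log units; that floor lies within the scatter), and because only its floor is known, it does not establish a change beyond the scatter, although it does show that the group that enters still allows a measurable effect. Compound 1 remains a limit of the assay, so the full size of the step stays unknown: the limit of > 200000 nM in this assay, at which 1 of the 3 values shown sits.

The group that enters differs from the one that leaves both in its six-membered aromatic ring, which now has 1 hetero atom, and in carrying 1 hydrogen-bond donor instead of 0 hydrogen-bond donors, and the compounds shown do not separate these two differences. Steps to compound 2 cannot be read, since it has no reported result, and it stays open how an amide in place of the carboxylic acid would read in this assay.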